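The source may report more compounds than this note shows. Statements on the series, on what has been measured and on what is new or still open speak of the compounds shown alone.

Measured in an ADME assay on microsomes from liver (Mus musculus) for metabolic stability, read by LC-MS, with a stated time of 30 min, tested at 1 uM (on this read-out lower numbers stand for a less stable compound and higher numbers for a more stable compound), so far: compound 1 `Cn1c(C(=O)NCc2ccc(S(=O)(=O)c3ccccc3)cc2)cc2cnccc21` gives 34%; compound 2 `O=C(NCc1ccc(S(=O)(=O)c2ccccc2)cc1)c1cc(-c2cccnc2)[nH]n1` gives 42%; compound 3 `O=C(NCc1ccc(S(=O)(=O)N2CCCCC2)cc1)c1cc2cnccc2s1` has no single number.

For compound 3 the read-out is "below limit of detection" (no number reported), so no number is given for it. Compound 3 therefore stands at the unstable end of what is shown; where it lies against compound 1 and compound 2 cannot be placed more closely.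

Compound 4 `O=C(NCc1ccc(S(=O)(=O)N2CCCCC2)cc1)c1cc2ccncc2o1` differs from compound 3 in one place: a group of 9 heavy atoms (7 carbon, 1 nitrogen, 1 oxygen; one five-membered aromatic ring with 1 hetero atom, one six-membered aromatic ring with 1 hetero atom) in place of a group of 9 heavy atoms (7 carbon, 1 nitrogen, 1 sulfur; one five-membered aromatic ring with 1 hetero atom, one six-membered aromatic ring with 1 hetero atom), on a carbonyl carbon. Within the data shown here, no step between measured compounds covers this change, so the size of the step in this assay is not known from the series; a small step in either direction, or none beyond the scatter, is expected, with the outcome for compound 4 likely staying low. Compound 4 is estimated at 10%, expected between 0% and 30%.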

Compound 4, percent of the compound remaining: 0.14%
Compound 4: the middle estimate sits 9.9 percentage points above what was measured, within the range that was stated.
By their numbers in this assay, from the lowest: compound 4; then compounds 1 and 2 (each within the scatter of the next).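

Among these compounds, compound 3 has no single number, so no step to compound 4 can be read. The compounds shown leave open how far swapping the sulfur-containing group for the oxygen-containing one shifts stability. No measured evidence bears on this result.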